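Removing One Fluorine from Compound 2

The source may hold more compounds than are shown below. What is called first, only, known or untested is meant among the compounds shown, and "the series" means these compounds.

Of the compounds shown here, three sharing one core have so far been measured in a functional assay on SK-OV-3 cells (Homo sapiens) for cytotoxicity; a lower number here means a stronger inhibitor of growth, a higher number a weaker inhibitor of growth. Compound 1 `COc1ccc(C2=C(c3cc(OC)c(OC)c(OC)c3)CC3CCCN3C2=O)cc1O` sits at the limit of > 100000 nM in this assay, at which 1 of the 3 values shown sits; its value of > 100000 nM is a limit of the assay and not a number. Compound 3 `COc1ccc(C2=C(c3ccc(SC)cc3)CC3CCCN3C2=O)cc1OC` gives 9000 nM in this assay. Compound 2 `CSc1ccc(C2=C(c3ccc(F)c(F)c3)C(=O)N3CCCC3C2)cc1` gives 100 nM, the lowest of the two numbers, and its gap to compound 3 lies beyond the usual scatter. Among the compounds with values here, no two measured compounds differ in a single place, so no measured step guides the change considered here.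

Compound 4 `CSc1ccc(C2=C(c3ccc(F)cc3)C(=O)N3CCCC3C2)cc1` differs from compound 2 by hydrogen in place of fluoro on an aromatic carbon: cut one bond further out, the change reads 3,4-difluorophenyl to 4-fluorophenyl. A change of one heavy atom with no ring, donor or acceptor gained or lost is expected to shift the number only slightly; the estimated step is a 2.0-fold higher number from compound 2 to compound 4 (0.30 log units; within the scatter), a mild weakening that may not exceed the scatter. Compound 4 is therefore expected to give 200 nM in this assay, with a range from 50 nM to 800 nM.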

Compound 4, concentration for 50% growth inhibition: 30000 nM
Compound 4: the middle estimate sits 150-fold (2.18 log units) below what was measured; the whole stated range lies below it.
By their numbers in this assay, from the lowest: compound 2; then compound 3; then compound 4. At a limit, above all of these: compound 1.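

In this assay, within the data shown here, the change from 3,4-difluorophenyl to 4-fluorophenyl gives the first step between compounds differing in one place, and that step is large: a 300-fold higher number from compound 2 to compound 4 (2.48 log units; beyond the scatter). It shows that the number for this series can depend heavily on a single aromatic carbon, here one ortho to a fluoro group, even though the change involves one fluorine and no ring, donor or acceptor. Nothing given here accounts for the size of this step.

The compounds shown leave open whether fluoro itself is needed at this position, or whether chloro, methyl or a nitrile there would keep a number close to that of compound 2 at 100 nM. They also leave open how much the remaining fluoro group on that ring contributes, and whether this single step would hold on other compounds of the series.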